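This account rests on a few compounds, and the source may have more. Where it says the series, first, only, none or still open, it means among the compounds named here.

Among the measured compounds shown here, compound 2 `COc1cccc([C@H]2O[C@H](CC(=O)N(C)CC(=O)O)C(=O)N(CC(C)(C)CO)c3ccc(Cl)cc32)c1OC` gives -1% in a functional assay on the whole organism for inhibition, with Rattus norvegicus as the target, at a dose of 10 mg/kg by the oral route (a lower number here means less inhibition, a higher number more inhibition at the dose given (going by the name of the read-out)), the lowest of the two numbers measured so far. Its nearest neighbour is compound 1 `COc1cccc([C@H]2O[C@H](CC(=O)NCC(=O)O)C(=O)N(CC(C)(C)CO)c3ccc(Cl)cc32)c1OC`, which gives 14% in this assay. Compound 3 `COc1cccc([C@H]2O[C@H](CC(=O)N[C@@H](C)C(=O)O)C(=O)N(CC(C)(C)CO)c3ccc(Cl)cc32)c1OC` differs from compound 2 by (1-carboxyethyl)amino in place of (carboxymethyl)(methyl)amino on a carbonyl carbon; the nitrogen again carries a hydrogen, as in compound 1, while the methyl moves onto the chain carbon. Because a number 15 percentage points lower from compound 1 to compound 2 (beyond the scatter), a rise of similar size in this assay is expected for compound 3, a number 11 percentage points higher from compound 2 to compound 3 (beyond the scatter). Compound 3 is therefore estimated to give 10%, within -5% to 25%.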

Compound 3, a percentage reported as inhibition, in the whole organism at one dose (the size of the read-out at that dose, not a potency): 14%
The estimate for compound 3 lay 4 percentage points below the measured number, and the stated range covers the measured number.
By their numbers in this assay, from the lowest: compound 2; then compounds 1 and 3 (each within the scatter of the next).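

In this assay, moving the methyl from the amide-type nitrogen onto the chain carbon gives a number 15 percentage points higher from compound 2 to compound 3 (beyond the scatter), whereas adding a methyl to that chain carbon in compound 1 gives no change at the digits printed from compound 1 to compound 3 (within the scatter). Among these three compounds, then, the lower number goes with the methyl on the nitrogen, not with the methyl on the chain carbon. Nothing measured here explains this difference. Still open, from the compounds shown here alone, is how a larger group on that chain carbon, such as ethyl or phenyl, would read in this assay. Also open, going by these compounds, is the effect of the opposite configuration at the new stereocentre.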